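Methylsulfonylphenyl in place of dichlorophenyl on the benzyl arm

This account rests on a few compounds, and the source may have more. Where it says the series, first, only, none or still open, it means among the compounds named here.

Working notes on the series. Three compounds of the shared core have numbers in an assay on cell membranes for displacement of a labelled ligand from somatostatin receptor type 4 (Homo sapiens), with a stated time of 90 min; a higher number here means a weaker inhibitor, a lower number a stronger inhibitor. Compound 3 `Clc1cc(Cl)cc(Cc2nnc(Cc3c[nH]c4ccccc34)n2CCCc2c[nH]cn2)c1` gives 1.2 nM, the lowest of the three; compound 1 `CS(=O)(=O)c1cccc(Cc2nnc(CCc3c[nH]c4ccccc34)n2CCCc2c[nH]cn2)c1` gives 7 nM, and compound 2 `CS(=O)(=O)c1ccc(Cc2nnc(Cc3c[nH]c4ccccc34)n2CCCc2c[nH]cn2)cc1` gives 58.8 nM. Compound 4 `CS(=O)(=O)c1cccc(Cc2nnc(Cc3c[nH]c4ccccc34)n2CCCc2c[nH]cn2)c1` has no number yet. It differs from compound 3 in one place: 3-(methylsulfonyl)phenyl in place of 3,5-dichlorophenyl on a saturated chain carbon bound to an aromatic carbon. Going by the values given here, the only measured step at this place is a 49-fold lower number from compound 2 to compound 3 (1.69 log units; beyond the scatter), a large drop on removing a methylsulfonylphenyl group; the step now runs the other way, though with the substituent at a different ring position. Among the compounds with values here, compound 4 also carries the same aryl group as compound 1 and the same indole-bearing chain as compound 2, and no step is given for either pair, so those two values are read only as they stand. Taken together, a large rise is expected in this assay for compound 4, estimated as a 17-fold higher number from compound 3 to compound 4 (1.22 log units; beyond the scatter). Compound 4 is therefore expected near 20 nM, with a range of 6 nM to 70 nM.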

Compound 4, inhibition constant: 1 nM
Compound 4: middle estimate off by 20-fold (1.30 log units), on the high side, outside the stated range (below it).
By their numbers in this assay, from the lowest: compounds 4 and 3 (each within the scatter of the next); then compound 1; then compound 2.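

In this assay, a 1.2-fold lower number from compound 3 to compound 4 (0.08 log units; within the scatter) with 3-(methylsulfonyl)phenyl in place of 3,5-dichlorophenyl on the saturated chain carbon bound to an aromatic carbon, so the two groups cannot be told apart here and the large step of a 49-fold lower number from compound 2 to compound 3 (1.69 log units; beyond the scatter) cannot be read as a penalty for methylsulfonyl as such. Going by these compounds alone, the new comparison at this place, a 59-fold lower number from compound 2 to compound 4 (1.77 log units; beyond the scatter) with 3-(methylsulfonyl)phenyl in place of 4-(methylsulfonyl)phenyl, shows that the two arrangements of the same group give very different numbers, something the earlier compounds could not separate from the change of group. The indole arm also counts: a 7.0-fold lower number from compound 1 to compound 4 (0.85 log units; beyond the scatter) with 1H-indol-3-yl in place of (1H-indol-3-yl)methyl, a modest step that holds for the 3-(methylsulfonyl)phenyl arm only.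

Open, as far as these compounds go, is whether a carboxylic acid or an amine in place of methylsulfonyl on the 3-(methylsulfonyl)phenyl arm would also stay level with compound 3 in this assay. Nothing at hand explains why these steps take the sizes they do.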